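Swapping the Ester Group on the Ester Oxygen

The source may hold more compounds than are shown below. What is called first, only, known or untested is meant among the compounds shown, and "the series" means these compounds.

Of the compounds shown here, three sharing one core have been tested in an assay on isolated protein for inhibition of protein kinase C zeta type (Homo sapiens), with stated times of 1 h and 2.5 min, tested at 30 uM; on this read-out higher numbers stand for more inhibition at the one concentration tested (going by the name of the read-out) and lower numbers for less inhibition. Compound 1 `CCOC(=O)c1c(-c2ccc(OC)c(OC)c2)csc1N` gives 100%. Compound 2 `CCOC(=O)c1cscc1-c1ccc(OC)c(OC)c1` gives 3%, and compound 3 `COc1ccc(-c2csc(N)c2C(=O)Oc2ccccc2)cc1OC` gives 48%. Compound 3 therefore stands second highest of the three, below compound 1 and above compound 2, with both gaps beyond the scatter. Two single-point steps are known: a number 97 percentage points lower from compound 1 to compound 2 (beyond the scatter), and a number 52 percentage points lower from compound 1 to compound 3 (beyond the scatter). Compound 4 `COc1ccc(-c2csc(N)c2C(=O)OCc2cccc(C)c2)cc1OC` differs from compound 3 in one place: 3-methylbenzyl in place of phenyl on an oxygen next to a carbonyl group. The step that bears on this sits on the same oxygen and was large, the one from ethyl to phenyl. The amino step concerns another position and says nothing here. Among the compounds with values here, no step from phenyl onward at this oxygen has been measured, so the direction is uncertain; a moderate change is expected, leaning downward because a number 52 percentage points lower from compound 1 to compound 3 (beyond the scatter) already went down. This change is expected to read a number 8 percentage points lower from compound 3 to compound 4 (within the scatter). Compound 4 is thus estimated at 40%, between 10% and 75%.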

Compound 4, a percentage reported as inhibition, at one concentration (the size of the read-out at that concentration, not a potency): 67%
Compound 4: middle estimate off by 27 percentage points, on the low side; the measured number falls inside the stated range.
By their numbers in this assay, from the lowest: compound 2; then compound 3; then compound 4; then compound 1.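

In this assay the ester oxygen now carries three measured groups, and moving away from ethyl does not always lower the number. Going from phenyl to 3-methylbenzyl gives a number 19 percentage points higher from compound 3 to compound 4 (beyond the scatter) and so wins back part of the drop seen with phenyl. Even so, the ethyl ester stays ahead, with a number 33 percentage points lower from compound 1 to compound 4 (beyond the scatter) at the same oxygen, and no measurement at hand gives a reason for this order.

On these data alone, compound 4 brings in a saturated chain carbon and a ring methyl in a single change, and the share of each in the gain stays open. Plain benzyl would separate the two, while propyl or butyl would show how a longer chain without a ring compares with ethyl.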